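The source may report more compounds than this note shows. Statements on the series, on what has been measured and on what is new or still open speak of the compounds shown alone.

The measured compounds:
compound 1, `O=S(=O)(Nc1ccc2oc(-c3ccccc3)nc2c1)c1cccc(C(F)(F)F)c1`, gives > 100000 nM
compound 2, `O=S(=O)(Nc1ccc(-c2nc3ccccc3o2)cc1)c1cccc(Cl)c1`, gives > 100000 nM
compound 3, `O=S(=O)(Nc1ccc2oc(-c3ccccc3)nc2c1)c1cccc(Cl)c1`, gives 70000 nM

All three were tested in an ADME assay on HEK293 cells (Homo sapiens) for cytotoxicity, read by resazurin assay, with a stated time of 48 h; on this read-out higher numbers stand for lower toxicity in this test and lower numbers for higher toxicity in this test. For compound 1 the value > 100000 nM is a limit of the assay and not a number. For compound 2 the value > 100000 nM is likewise a limit. Compound 3 alone gives a number, 70000 nM. The change from compound 3 to compound 1 is trifluoromethyl in place of chloro on an aromatic carbon, and it brought an at least 1.4-fold higher number from compound 3 to compound 1 (0.15 log units; that floor lies within the scatter). The cores of compound 2 and compound 3 are built from the same atoms joined differently; how they differ is not broken down here.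

Compound 4, `O=S(=O)(Nc1ccc(-c2nc3ccccc3o2)cc1)c1cccc(C(F)(F)F)c1`, has not yet been measured. It stands to compound 2 as compound 1 stands to compound 3: trifluoromethyl in place of chloro on an aromatic carbon, the same change at the same kind of place. Since compound 2 already sits at the limit of > 100000 nM in this assay, at which 2 of the 3 values shown sit, the step from compound 2 to compound 4 can only be estimated, and the estimate is a step that the limit leaves unreadable from compound 2 to compound 4, resting on the measured step of an at least 1.4-fold higher number from compound 3 to compound 1 (0.15 log units; that floor lies within the scatter), which stayed within the scatter. Compound 4 is therefore expected to give 150000 nM in this assay, between 80000 nM and 300000 nM, and most likely to be reported again only as a limit.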

Compound 4, half-maximal cytotoxic concentration: > 100000 nM
Compound 4: only a limit was reported (the forecaster's own chance of this, stated with the estimate: 85%); the middle value is on the limit's open side.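

In this assay compound 4 gives > 100000 nM, which is a limit of the assay and not a number. Among these compounds, compound 2 also stands only at a limit, so no step from compound 2 to compound 4 can be read: the limit of > 100000 nM in this assay, at which 3 of the 4 values shown sit.

The compounds shown leave open where the true values of compound 2 and compound 4 lie beyond that limit, and whether trifluoromethyl in place of chloro changes anything on this core.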